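Two Chlorines on One Ring: What to Expect

This account rests on a few compounds, and the source may have more. Where it says the series, first, only, none or still open, it means among the compounds named here.

Measured so far:
compound 1, `Clc1cccc(C2=NC(c3ccccc3)CO2)c1`, 4.44
compound 2, `Clc1cccc(C2=NC(c3ccccc3)CO2)c1Cl`, 4.28
compound 3, `Clc1ccc(C2=NC(c3ccccc3)CO2)cc1`, 4.48

Of the compounds shown here, three have been measured in a physicochemical assay for lipophilicity; a lower number here means a more polar compound, a higher number a more lipophilic compound. Compound 1 and compound 2 share a core and differ in one place: chloro in place of hydrogen on an aromatic carbon. That change gave a number 0.16 log units lower from compound 1 to compound 2 (within the scatter), so the two numbers sit within the usual scatter of each other, and nothing can be read into their order. Compound 3 has the same atoms as compound 1 joined differently; how the two cores differ is not broken down here. In this assay compound 3 gives a number that is close to that of compound 1 and of compound 2, all three within the usual scatter.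

Compound 4, `Clc1ccc(C2=NC(c3ccccc3)CO2)c(Cl)c1`, has not yet been measured in this assay. It is related to compound 3 in this way: chloro in place of hydrogen on an aromatic carbon. For the measured compounds named here, this is the same kind of change as the one from compound 1 to compound 2, but not the same: in compound 2 the entering chloro sits ortho to a chloro group and ortho to a large group, while in compound 4 it sits meta to a chloro group and ortho to a large group. Since the measured step of this kind gave a number 0.16 log units lower from compound 1 to compound 2 (within the scatter), a step of about a number 0.08 log units lower from compound 3 to compound 4 (within the scatter) is expected from compound 3 to compound 4. Compound 4 is therefore estimated at 4.4, between 4.05 and 4.8.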

Compound 4, partition coefficient: 4.4
The estimate for compound 4 equals the measured number at the digits printed; the measured number falls inside the stated range.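

In this assay, placing a chloro on the core of compound 3 gave a number 0.08 log units lower from compound 3 to compound 4 (within the scatter), while the same kind of change on the core of compound 1 gave a number 0.16 log units lower from compound 1 to compound 2 (within the scatter). For the compounds shown here, both steps lie within the usual scatter, so on these two cores neither step can be told apart from no step at all, and in that limited sense the change carries over from one core to the other. This does not show that the two steps are truly equal in size, nor that the change would behave alike on any further core, and the entering chloro does not have the same surroundings in the two pairs, so two pairs make no rule, and nothing on hand explains either number.

The compounds shown carry only chloro on the substituted ring, so how this assay would respond to a fluoro, a methoxy, an amine or a carboxylic acid in the same place stays open. Also open, going by these compounds, is what a chloro would do elsewhere on the shared core, outside the ring that carries it in these four compounds.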